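Cyano for methoxy on the benzyl of compound 1

A few compounds are considered here, and "the series" means these few. Any claim that something is new, unique, unknown or untested is made for them only; others in the source may bear on it.

Compound 1 `COc1ccc(Cn2cc(CO/N=C/c3c(-c4ccccc4)nc4c(C)cccn34)nn2)cc1` is the reference point here. In a functional assay on the whole organism (strain NMRI) with Mus musculus as the target, with a stated time of 4 h (on this read-out higher numbers stand for an effect only at larger amounts of compound and lower numbers for an effect already at smaller amounts), compound 1 gives 100 mg/kg, the same figure as compound 3 `COc1ccc(Cn2cc(CO/N=C/c3c(-c4ccc(C)cc4)nc4c(C)cccn34)nn2)cc1`, which gives 100 mg/kg; together these two carry the highest numbers among the three measured compounds. For the measured compounds named here, compound 2 `Cc1ccc(-c2nc3ccc(Br)cn3c2/C=N/OCc2cn(Cc3ccc([N+](=O)[O-])cc3)nn2)cc1` differs from compound 1 in several places at once, and no single-point step connects the two. In this assay compound 2 gives 20 mg/kg, a lower number beyond the scatter.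

The new compound 4 `Cc1cccn2c(/C=N/OCc3cn(Cc4ccc(C#N)cc4)nn3)c(-c3ccccc3)nc12` arises from compound 1 by one change: cyano in place of methoxy on an aromatic carbon The methoxy leaves and a cyano enters on an aromatic carbon of the six-membered aromatic ring of carbon only, para to a large group.

Going by the values given here, no measured step touches this exchange. Among the compounds with values here, the only single-point step available, no change at the digits printed from compound 1 to compound 3 (within the scatter), concerns methyl in place of hydrogen on an aromatic carbon elsewhere in the shared core and shows no change within the scatter. That step says nothing about cyano for methoxy, so the expectation rests on the unchanged remainder of the structure and on the value of compound 1. For compound 4 the expected step is no change at the digits printed from compound 1 to compound 4 (within the scatter), that is, no shift beyond the scatter. The estimate for compound 4 is 100 mg/kg, with a range from 50 mg/kg to 200 mg/kg.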

Compound 4, minimum effective dose: 40 mg/kg
Compound 4: the middle estimate sits 2.5-fold (0.40 log units) above what was measured; measured number outside the range, below it.
By their numbers in this assay, from the lowest: compounds 2 and 4 (each within the scatter of the next); then compounds 1 and 3 (each within the scatter of the next).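

In this assay, for the compounds shown here, the exchange of 4-methoxybenzyl for 4-cyanobenzyl gives a 2.5-fold lower number from compound 1 to compound 4 (0.40 log units; beyond the scatter), the first single-point evidence that the substituent on this six-membered aromatic ring of carbon only, para to a large group, moves the number; the earlier step, no change at the digits printed from compound 1 to compound 3 (within the scatter), lay elsewhere in the shared core and stayed within the scatter. The step appears although the leaving methoxy and the entering cyano match in heavy atoms and in hydrogen-bond acceptors, so those counts do not separate the two groups, while the read-out does. No measurement at hand accounts for the step, and the reason for it stays unknown.

As far as these compounds go, it remains open whether the same exchange gives a similar step on the background of compound 3, and whether an amine or a carboxylic acid at this place would shift the number further, leave it level or reverse it. The nitro group of compound 2 stands on a benzyl too, but compound 2 differs from compound 1 in several places at once, so its value cannot be read as an effect of this position alone.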